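The compounds below may be only part of what the source reports. "The series", "measured", "known", "first", "only" and "open" are said of these compounds alone.

Of the compounds shown here, two have so far been tested in a functional assay on CHO cells for agonist activity at hydroxycarboxylic acid receptor 1 (Homo sapiens), read by cAMP accumulation; on this read-out higher numbers stand for an effect only at larger amounts of compound and lower numbers for an effect already at smaller amounts. Compound 1, `CN1CCC(S(=O)(=O)c2ccc3nc(NC(=O)NC(=O)c4cc(-n5cccn5)ccc4Cl)sc3c2)CC1`, gives 7000 nM in this assay. Compound 2, `CCOc1cc(Cl)c(C(=O)Nc2nc3ccc(S(=O)(=O)CCCN4CCN(C)CC4)cc3s2)cc1N1C[C@H](C)O[C@@H](C)C1`, gives 270 nM in this assay, which is the lower of the two numbers and stands apart from compound 1 by a margin beyond the scatter.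

Compound 3, `CCOc1cc(Cl)c(C(=O)Nc2nc3ccc(S(=O)(=O)CCCN4CCN(C)CC4)cc3s2)cc1N1C[C@@H](C)O[C@@H](C)C1`, is the next compound to be examined. Relative to compound 2 the change is the two compounds have the same atoms and bonds and differ only in configuration as drawn: 1 of 2 stereo elements differ; a stereocentre at a saturated ring carbon is drawn S in compound 2 and R in compound 3, so nothing is added or removed and only the drawn configuration at one saturated ring carbon changes.

Within the data shown here, no measured pair in this set isolates such a change, so the size of the step is uncertain. Compound 3 is expected to give 500 nM in this assay, within a range from 150 nM to 2500 nM. The expected step is a 1.9-fold higher number from compound 2 to compound 3 (0.27 log units; within the scatter), a modest loss that may still fall within the scatter.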

Compound 3, half-maximal effective concentration in the hydroxycarboxylic acid receptor 1 assay: 54 nM
Beside the measured number, compound 3's estimate is 9.3-fold (0.97 log units) above it, and the stated range ends above it.
By their numbers in the hydroxycarboxylic acid receptor 1 assay, from the lowest: compound 3; then compound 2; then compound 1.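

In the hydroxycarboxylic acid receptor 1 assay the series now has a pair that isolates a single stereocentre at a saturated ring carbon (compound 2 at 270 nM and compound 3 at 54 nM), and redrawing that stereocentre from S to R gives a 5.0-fold lower number from compound 2 to compound 3 (0.70 log units; beyond the scatter). Nothing enters or leaves, so this step, beyond the scatter, can be traced to one source: the fact that compounds 2 and 3 differ only in the configuration as drawn. In a physicochemical assay for lipophilicity, at pH 7.4; on this read-out lower numbers stand for lower lipophilicity and higher numbers for higher lipophilicity (compound 2 at 3 and compound 3 at 2.7) the same change gives a number 0.30 log units lower from compound 2 to compound 3 (within the scatter), a step within the scatter, so only the receptor read-out separates the two compounds.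

The compounds shown leave open what inverting the second stereocentre of that ring, alone or together with the first, would do to the number. They also leave open whether an ethyl or a hydroxymethyl group on that ring carbon would keep the lower number seen for compound 3.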